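Alanine to isoleucine side chain on two related cores

The source may report more compounds than this note shows. Statements on the series, on what has been measured and on what is new or still open speak of the compounds shown alone.

Compound 1 `COC(=O)[C@H](C)NC(=O)c1ccc(Oc2nc3ccccc3nc2C)cc1` and compound 2 `CC[C@@H](C)[C@H](NC(=O)c1ccc(Oc2nc3ccccc3nc2C)cc1)C(=O)OC` share one core and differ in a single place: sec-butyl in place of methyl on a saturated chain carbon bound to an amide-type nitrogen and a carbonyl carbon In a functional assay on MCF7 cells (Homo sapiens) for antiproliferative activity, read by MTT assay, with a stated time of 48 h (on this read-out higher numbers stand for weaker inhibition and lower numbers for stronger inhibition), compound 1 gives 38400 nM and compound 2 gives 36100 nM so that the step of a 1.1-fold lower number from compound 1 to compound 2 (0.03 log units; within the scatter) is a flat one. Compound 3 `CCCCCCCCCCCCNc1nc2ccccc2nc1Oc1ccc(C(=O)N[C@@H](C)C(=O)O)cc1` is built on a different core; how its core differs from that of compound 1 is not broken down here. In this assay compound 3 gives 4110 nM the lowest of the three numbers, and its distance from compound 1 and from compound 2 lies beyond the scatter. Compound 4 `CCCCCCCCCCCCNc1nc2ccccc2nc1Oc1ccc(C(=O)N[C@H](C(=O)O)[C@H](C)CC)cc1` has not been measured. It differs from compound 3 in exactly the same way that compound 2 differs from compound 1: sec-butyl in place of methyl on a saturated chain carbon bound to an amide-type nitrogen and a carbonyl carbon The place of the change is identical word for word in both pairs, so it counts as the same change, only now on the core of compound 3 rather than that of compound 1. Within the data shown here, the one measured instance of this change, from compound 1 to compound 2, moved the number by an amount within the scatter; it is therefore expected that the step of a 1.1-fold lower number from compound 3 to compound 4 (0.05 log units; within the scatter) will be similarly small, resting on compound 3 at 4110 nM as its anchor. Compound 4 is accordingly estimated at 3700 nM in this assay with a range from 1500 nM to 9500 nM expected to cover most repeat measurements.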

Compound 4, half-maximal inhibitory concentration: 30400 nM
Estimate against measurement, compound 4: 8.2-fold (0.91 log units) below, outside the stated range (above it).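

On the core of compound 3, replacing methyl with sec-butyl on a saturated chain carbon bound to an amide-type nitrogen and a carbonyl carbon did not leave the number flat in this assay; the result was a 7.4-fold higher number from compound 3 to compound 4 (0.87 log units; beyond the scatter). Set beside its counterpart on the core of compound 1, the same change did not carry over from one core to the other: the same change on two cores in this assay, a 1.1-fold lower number (0.03 log units; within the scatter) from compound 1 to compound 2 and a 7.4-fold higher number (0.87 log units; beyond the scatter) from compound 3 to compound 4, 7.9-fold (0.90 log units) apart, beyond the scatter of two such steps

The flat step on the core of compound 1 was therefore no reliable guide to the size of this change on the core of compound 3, but the comparison rests on one pair per core and shows neither why the two steps part nor how the change would behave on any further core.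

The compounds shown leave open which difference between the two cores goes with the divergence, as they do not separate the long chain on the core of compound 3 from its carboxylic acid, which stands where compounds 1 and 2 carry a methyl ester. They also leave open where other side chains in the same place, such as isopropyl or benzyl, would fall on either core.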